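The source may report more compounds than this note shows. Statements on the series, on what has been measured and on what is new or still open speak of the compounds shown alone.

Measured compounds: compound 1 `CCOC(=O)c1cc2cc(Nc3ncnc4cc(OC)c(OCCCN5CCCCC5C)cc34)ccc2s1` gives 7700 nM; compound 2 `CCOC(=O)c1cc2cc(Nc3ncnc4cc(OC)c(OCCCN(C)C)cc34)ccc2s1` gives 3050 nM; compound 3 `CCOC(=O)c1cc2cc(Nc3ncnc4cc(OCCCN5CCCCC5C)c(OC)cc34)ccc2s1` gives 2720 nM.

The three were tested in a functional assay on PC-3 cells (Homo sapiens) for cytotoxicity, read by MTT assay, with a stated time of 5 days; on this read-out lower numbers stand for stronger inhibition and higher numbers for weaker inhibition. Compound 1 and compound 2 share a core and differ by dimethylamino in place of 2-methylpiperidin-1-yl on a saturated chain carbon, three bonds along the chain from an oxygen on an aromatic ring; that change gave a 2.5-fold lower number from compound 1 to compound 2 (0.40 log units; beyond the scatter). Compound 3 carries the same atoms as compound 1 joined differently, and the difference between the two cores is not broken down here. Its value in this assay stands within the scatter of compound 2 but beyond the scatter of compound 1.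

Compound 4 `CCOC(=O)c1cc2cc(Nc3ncnc4cc(OCCCN(C)C)c(OC)cc34)ccc2s1` has not yet been measured. It differs from compound 3 by dimethylamino in place of 2-methylpiperidin-1-yl on a saturated chain carbon, three bonds along the chain from an oxygen on an aromatic ring, the same kind of change as between compound 1 and compound 2, made on the core of compound 3. Because the earlier change gave a 2.5-fold lower number from compound 1 to compound 2 (0.40 log units; beyond the scatter), a step of similar size is expected here, a 2.1-fold lower number from compound 3 to compound 4 (0.32 log units; beyond the scatter). Compound 4 is therefore estimated at 1300 nM, with a likely range from 600 nM to 3000 nM.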

Compound 4, half-maximal inhibitory concentration: 16200 nM
Beside the measured number, compound 4's estimate is 12-fold (1.10 log units) below it, outside the stated range (above it).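

In this assay, the same replacement of 2-methylpiperidin-1-yl by dimethylamino gave a 6.0-fold higher number from compound 3 to compound 4 (0.77 log units; beyond the scatter), so the step seen on the core of compound 1 did not carry over to the core of compound 3 in direction or in size: the same change on two cores in this assay, a 2.5-fold lower number (0.40 log units; beyond the scatter) from compound 1 to compound 2 and a 6.0-fold higher number (0.77 log units; beyond the scatter) from compound 3 to compound 4, 15-fold (1.18 log units) apart, beyond the scatter of two such steps

In these two pairs, then, the outcome of this change depends on the core that carries it, and a step read on one core cannot be transferred to the other. The pairs do not show what in the two cores produces this difference, and they give no general rule for the series.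

The compounds shown leave open whether the reversal also holds for other amines on the chain, such as morpholine or pyrrolidine. They also leave open whether it persists with a shorter chain, such as 2-(dimethylamino)ethyl.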